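Trifluoromethoxy in place of trifluoromethyl, tried a second time

The source may report more compounds than this note shows. Statements on the series, on what has been measured and on what is new or still open speak of the compounds shown alone.

Compound 1 `CC(O)(CSc1ccc(C(F)(F)F)cc1)C(=O)Nc1cccc(S(F)(F)(F)(F)F)c1` and compound 2 `CC(O)(CSc1ccc(OC(F)(F)F)cc1)C(=O)Nc1cccc(S(F)(F)(F)(F)F)c1` share one core; compound 3 `CC(O)(COc1ccc(C(F)(F)F)cc1)C(=O)Nc1cccc(S(F)(F)(F)(F)F)c1` and compound 4 `CC(O)(COc1ccc(OC(F)(F)F)cc1)C(=O)Nc1cccc(S(F)(F)(F)(F)F)c1` share another. How the core of compound 1 differs from the core of compound 3 is not broken down here.

In a functional assay on DU-145 cells (Homo sapiens) for antiproliferative activity, read by propidium iodide staining, with a stated time of 96 h (a lower number here means a stronger inhibitor, a higher number a weaker inhibitor), compound 1 gives 27200 nM, and compound 2 gives 24700 nM. The change between the two, (trifluoromethoxy in place of trifluoromethyl on an aromatic carbon), made a step of a 1.1-fold lower number from compound 1 to compound 2 (0.04 log units; within the scatter). Compound 3 gives 13600 nM in this assay. Its gaps to compound 1 and to compound 2 are within the scatter, so no order among the three is claimed.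

Compound 4 has not yet been measured. It carries the same change as compound 2, (trifluoromethoxy in place of trifluoromethyl on an aromatic carbon), and the place is described in the same words, so this is the same change on a second core. The step from compound 3 to compound 4 is expected to be a 1.1-fold lower number from compound 3 to compound 4 (0.04 log units; within the scatter), resting on the one earlier occurrence, a 1.1-fold lower number from compound 1 to compound 2 (0.04 log units; within the scatter), with the caution that a single prior instance is a thin base. Compound 4 is therefore estimated at 12500 nM in this assay. The expected range for compound 4 runs from 6000 nM to 27000 nM.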

Compound 4, half-maximal inhibitory concentration: 19100 nM
The estimate for compound 4 lay 1.5-fold (0.18 log units) below the measured number; the measured number falls inside the stated range.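

In this assay, trifluoromethoxy in place of trifluoromethyl on the second core gives a 1.4-fold higher number from compound 3 to compound 4 (0.15 log units; within the scatter). Set beside the earlier step, this one does not differ from it beyond the scatter: the same change on two cores in this assay, a 1.1-fold lower number (0.04 log units; within the scatter) from compound 1 to compound 2 and a 1.4-fold higher number (0.15 log units; within the scatter) from compound 3 to compound 4, 1.5-fold (0.19 log units) apart, within the scatter of two such steps

On these two cores, then, the change carries over without any measurable dependence on the core, and neither step can be read as a real gain or loss, so the two opposite signs carry no meaning. This does not show that the two groups are interchangeable across the series, since two cores are a small base and steps this small could hide a modest effect of either sign.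

As far as these compounds go, whether a nitrile, an amine or a carboxylic acid in the same place on the aromatic ring would give a step beyond the scatter remains open. Also open, from the compounds shown here alone, is whether the near-absence of a step would hold on a third core.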